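Fluoro to Cyclopropyl: Estimating an Untested Analogue

This account rests on a few compounds, and the source may have more. Where it says the series, first, only, none or still open, it means among the compounds named here.

compound 1 `COc1cc(/C=C/C(=O)Nc2nc(-c3c(C)cc(C)cc3C)cs2)cc(OC)c1OC`: 11800 nM
compound 2 `Cc1cc(C)c(-c2csc(NC(=O)/C=C/c3ccc(F)cc3)n2)c(C)c1`: 14000 nM
compound 3 `Cc1cc(C)c(-c2csc(NC(=O)/C=C/c3ccc(Cl)c(C(F)(F)F)c3)n2)c(C)c1`: 3060 nM

These three compounds were tested in a functional assay on K562 cells (Homo sapiens) for inhibition, read by MTT assay, with a stated time of 96 h; a higher number here means a weaker inhibitor, a lower number a stronger inhibitor. Compound 2 gives 14000 nM, the highest of the three numbers; compound 1 sits within the scatter of it, while compound 3, which carries chloro and trifluoromethyl, gives a clearly lower number. Compound 4 `Cc1cc(C)c(-c2csc(NC(=O)/C=C/c3ccc(C4CC4)cc3)n2)c(C)c1` has not yet been measured. It differs from compound 2 by cyclopropyl in place of fluoro on an aromatic carbon. For the measured compounds named here, no measured pair shows this exact change, so the expectation leans on compound 3, whose value 3060 nM shows that a different group on the same ring can lower the number. Compound 4 is estimated at 7000 nM, between 2500 nM and 20000 nM. The expected step is a 2.0-fold lower number from compound 2 to compound 4 (0.30 log units; within the scatter), a modest lowering that may not exceed the scatter.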

Compound 4, half-maximal inhibitory concentration: 380 nM
Beside the measured number, compound 4's estimate is 18-fold (1.27 log units) above it; measured number below the stated range.
By their numbers in this assay, from the lowest: compound 4; then compound 3; then compounds 1 and 2 (each within the scatter of the next).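

Cyclopropyl in place of fluoro gives a 37-fold lower number from compound 2 to compound 4 (1.57 log units; beyond the scatter) in this assay as the only change. For the compounds shown here, the earlier compounds differ from one another in more than one place, so this is the first clean reading at this ring position, para to a large group, and it shows that this single replacement can move the number strongly. Nothing measured here explains the size of the step. The compounds shown leave open whether an ethyl group, a cyclobutyl ring or an amine at this position would give a similar number.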